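From Trifluoroethyl to 1-(tert-butyl)azetidin-3-yl on the Oxygen

The source may report more compounds than this note shows. Statements on the series, on what has been measured and on what is new or still open speak of the compounds shown alone.

Compound 1 `CCOc1cc(-c2ccc3[nH]ccc3c2)cn2c(-c3cc(OC)c(OC)c(OC)c3)nnc12`: 374 nM
Compound 2 `COc1cc(-c2nnc3c(OC4COC4)cc(-c4ccc5[nH]ccc5c4)cn23)cc(OC)c1OC`: 5370 nM
Compound 3 `COc1cc(-c2nnc3c(OCC(F)(F)F)cc(-c4ccc5[nH]ccc5c4)cn23)cc(OC)c1OC`: 900 nM

These values come from a functional assay on HCT-116 cells (Homo sapiens) for antiproliferative activity, read by MTT assay, with a stated time of 48 h (a higher number here means a weaker inhibitor, a lower number a stronger inhibitor), and the three compounds differ only in the group on one oxygen of the shared core. Compound 3, at 900 nM, holds the middle place, above compound 1 and below compound 2. Compound 4 `COc1cc(-c2nnc3c(OC4CN(C(C)(C)C)C4)cc(-c4ccc5[nH]ccc5c4)cn23)cc(OC)c1OC` is the next case, with 1-(tert-butyl)azetidin-3-yl in place of 2,2,2-trifluoroethyl on an oxygen on an aromatic ring.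

All three measured steps bear on this change. Compound 2 is the closest case, as its oxetan-3-yl group also puts a four-membered ring on that oxygen, and the measured change there is a 14-fold higher number from compound 1 to compound 2 (1.16 log units; beyond the scatter). Leaving that group for 2,2,2-trifluoroethyl gave a 6.0-fold lower number from compound 2 to compound 3 (0.78 log units; beyond the scatter), while the fluorine-bearing group itself cost less, with a 2.4-fold higher number from compound 1 to compound 3 (0.38 log units; beyond the scatter). Within the data shown here, no measured compound has a nitrogen in this group, so the precedent is only partial. A modest to large rise in this assay is therefore expected, and the estimated step is a 2.8-fold higher number from compound 3 to compound 4 (0.44 log units; beyond the scatter). Compound 4 is estimated at 2500 nM, with an expected range of 500 nM to 10000 nM.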

Compound 4, half-maximal inhibitory concentration: > 10000 nM
Compound 4 was reported as a limit; the forecaster's own chance of this, stated with the estimate: 10%; at least 4.0-fold (0.60 log units) between middle value and limit.
By their numbers in this assay, from the lowest: compound 1; then compound 3; then compound 2. At a limit, above all of these: compound 4.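

In this assay compound 4 stands at a limit and not at a number: the limit of > 10000 nM in this assay, at which 1 of the 4 values shown sits.

Replacing 2,2,2-trifluoroethyl with 1-(tert-butyl)azetidin-3-yl on this oxygen gives an at least 11-fold higher number from compound 3 to compound 4 (1.04 log units; beyond the scatter), and the same group in place of ethyl gives an at least 26-fold higher number from compound 1 to compound 4 (1.42 log units; beyond the scatter), so both open-chain groups shown sit well clear of this one in this assay. Against oxetan-3-yl, the other group with a four-membered ring, the result is an at least 1.8-fold higher number from compound 2 to compound 4 (0.27 log units; that floor lies within the scatter), a floor that leaves compound 2 and compound 4 unordered, although the two compounds with a four-membered ring on this oxygen both give higher numbers than compound 1 and compound 3.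

The compounds shown leave open whether the rise goes with the four-membered ring, the ring nitrogen or the tert-butyl group. An azetidin-3-yl with a hydrogen on its nitrogen, a cyclobutyl group and an open-chain amine such as 2-(dimethylamino)ethyl on the same oxygen would separate these three parts.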